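Replacing Benzylamino With Methoxyethoxy: Outlook for Cytotoxicity

The source may report more compounds than this note shows. Statements on the series, on what has been measured and on what is new or still open speak of the compounds shown alone.

compound 1 `CCCNc1nc(N)nc2c1ncn2/C=C1/CC1(CO)CO` — in an ADME assay on BCBL1 cells (Homo sapiens) for cytotoxicity, with a stated time of 7 days (on this read-out lower numbers stand for higher toxicity in this test and higher numbers for lower toxicity in this test), compound 1 gives > 20000 nM, a limit of the assay rather than a number.
compound 2 `CCCOc1nc(N)nc2c1ncn2/C=C1/CC1(CO)CO` — in this assay compound 2 gives > 20000 nM, also a limit of the assay.
compound 3 `Nc1nc(NCc2ccccc2)c2ncn(/C=C3/CC3(CO)CO)c2n1` — in this assay compound 3 gives 19900 nM.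

Compound 3 is the only one of the three whose toxicity came out as a number; the other two sit at the limit of > 20000 nM in this assay, at which 2 of the 3 values shown sit. The step of a number no higher from compound 1 to compound 3 (the limit leaves the size open) and the step of a number no higher from compound 2 to compound 3 (the limit leaves the size open) each run from a limit to a number, so their sizes cannot be read, and the step that the two limits leave unreadable from compound 1 to compound 2 runs between two limits and is equally unreadable. Compound 4 `COCCOc1nc(N)nc2c1ncn2/C=C1/CC1(CO)CO` differs from compound 3 in one place: 2-methoxyethoxy in place of benzylamino on an aromatic carbon. This change brings compound 4 close to compound 2, which carries a propoxy group on the same aromatic carbon and sits at the limit. With no readable step to lean on, the expected step of a 1.1-fold higher number from compound 3 to compound 4 (0.04 log units; within the scatter) is toward lower toxicity, and a limit is the most likely outcome. For compound 4 the estimated value is 22000 nM, with a range from 10000 nM to 45000 nM.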

Compound 4, half-maximal cytotoxic concentration: > 20000 nM
Compound 4: no number, only a limit (the forecaster's own chance of this, stated with the estimate: 70%); the middle value is on the limit's open side.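

Compound 4 is a third compound, after compound 1 with propylamino and compound 2 with propoxy, that gives a limit of the assay rather than a number, so 2-methoxyethoxy on this aromatic carbon joins that group. Compound 3, with benzylamino, remains the only one of the four with a measured number, and the results now cluster at one limit: the limit of > 20000 nM in this assay, at which 3 of the 4 values shown sit.

None of the new steps can be read, so neither the size of the change from benzylamino to 2-methoxyethoxy nor any order among the three groups at the limit can be taken from these results.

As far as these compounds go, how far compound 1, compound 2 and compound 4 lie from compound 3 remains open. In this assay, the change from benzylamino to 2-methoxyethoxy gives a number no lower from compound 3 to compound 4 (the limit leaves the size open).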